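A few compounds are considered here, and "the series" means these few. Any claim that something is new, unique, unknown or untested is made for them only; others in the source may bear on it.

Measured compounds:
- compound 1, `ClCc1ccccc1Cn1cnc2c(Cl)ncnc21`: 6600 nM in a functional assay on OVCAR-5 cells (Homo sapiens) for cytotoxicity, read by sulforhodamine B assay, with a stated time of 48 h; on this read-out lower numbers stand for stronger inhibition of growth and higher numbers for weaker inhibition of growth
- compound 2, `ClCc1ccc(Cn2cnc3nc(Cl)nc(Cl)c32)cc1`: 4260 nM in this assay

Compound 2 and compound 1 give numbers within the scatter of each other, so neither can be set apart on this assay. Compound 3, `ClCc1ccc(Cn2cnc3ncnc(Cl)c32)cc1`, differs from compound 2 in one place: hydrogen in place of chloro on an aromatic carbon. Among the compounds with values here, no step of this kind has been measured, so the direction is open; a step of modest size, or none beyond the scatter, is expected. For compound 3 the estimate is 6000 nM, between 2500 nM and 15000 nM, which is a step of a 1.4-fold higher number from compound 2 to compound 3 (0.15 log units; within the scatter).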

Compound 3, concentration for total growth inhibition: 19500 nM
The estimate for compound 3 lay 3.3-fold (0.51 log units) below the measured number; the whole stated range lies below it.
By their numbers in this assay, from the lowest: compounds 2 and 1 (each within the scatter of the next); then compound 3.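

Within the data shown here, the aromatic carbon between two ring nitrogen atoms is the first place where a single change can be read. In this assay, hydrogen in place of chloro gives a 4.6-fold higher number from compound 2 to compound 3 (0.66 log units; beyond the scatter), so in this pair the chloro group on this carbon goes with the lower number. Nothing measured here says why the number moves.

On these data alone, whether an amine or a methoxy group on this carbon would keep the lower number remains open. So does the effect of changing the remaining chloro group.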